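Replacing the Cyclic Sulfone Amide with a Methoxypyrrolidine

A few compounds are considered here, and "the series" means these few. Any claim that something is new, unique, unknown or untested is made for them only; others in the source may bear on it.

Measured so far:
Compound 1 `CCN(CC)S(=O)(=O)c1ccc(S(=O)(=O)N2CCC[C@@H](C(=O)NC3COC3)C2)cc1`: 2340 nM
Compound 2 `CCN(CC)S(=O)(=O)c1ccc(S(=O)(=O)N2CCC[C@@H](C(=O)N3CCS(=O)(=O)CC3)C2)cc1`: 900 nM

In a functional assay on MIA PaCa-2 cells (Homo sapiens) for inhibition, read by MTT assay, with a stated time of 7 days (on this read-out higher numbers stand for weaker inhibition and lower numbers for stronger inhibition), compound 2 gives the lowest of the two numbers, and compound 1 stands the next nearest, separated by a 2.6-fold lower number from compound 1 to compound 2 (0.41 log units; beyond the scatter). Compound 3 `CCN(CC)S(=O)(=O)c1ccc(S(=O)(=O)N2CCC[C@@H](C(=O)N3CC[C@@H](OC)C3)C2)cc1` differs from compound 2 in one place: 3-methoxypyrrolidin-1-yl in place of 1,1-dioxothiomorpholin-4-yl on a carbonyl carbon. Among the compounds with values here, only the step from compound 1 to compound 2 bears on this change, and it exchanged an amide of a different kind; compound 3 keeps a tertiary cyclic amide like compound 2, so little movement beyond the scatter is expected, a 1.1-fold higher number from compound 2 to compound 3 (0.05 log units; within the scatter). Compound 3 is therefore estimated at 1000 nM, within 400 nM to 2500 nM.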

Compound 3, half-maximal inhibitory concentration: 3910 nM
Beside the measured number, compound 3's estimate is 3.9-fold (0.59 log units) below it; measured number outside the range, above it.
By their numbers in this assay, from the lowest: compound 2; then compounds 1 and 3 (each within the scatter of the next).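

In this assay, a tertiary amide at this carbonyl carbon is not enough to hold the activity of compound 2 (a 4.3-fold higher number from compound 2 to compound 3 (0.64 log units; beyond the scatter)), so the outcome depends on which ring the amide carries. Compound 3 also shows no separation from the secondary amide compound 1 (a 1.7-fold higher number from compound 1 to compound 3 (0.22 log units; within the scatter)), leaving 1,1-dioxothiomorpholin-4-yl as the only group shown here that stands apart. Nothing available explains this difference. From the compounds shown here alone, whether a morpholine or an unsubstituted piperidine on the same carbonyl carbon would fall with compound 2 or with compound 3 remains open, as does the effect of the opposite configuration at the methoxy-bearing carbon.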